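Swapping the aryl ring on the thiazolidine core

The source may report more compounds than this note shows. Statements on the series, on what has been measured and on what is new or still open speak of the compounds shown alone.

Compound 1 `CCCCCCCCCCCCCCCCCCNC(=O)[C@H]1CSC(c2cccc(O)c2)N1` carries a 3-hydroxyphenyl on a saturated ring carbon of the shared core; in a functional assay on PPC-1 cells (Homo sapiens) for antiproliferative activity, read by sulforhodamine B assay (a higher number here means a weaker inhibitor, a lower number a stronger inhibitor), compound 1 gives 1200 nM. Among the compounds with values here, compound 2 `CCCCCCCCCCCCCCCCCCNC(=O)[C@H]1CSC(c2ccc(C#N)cc2)N1` carries a 4-cyanophenyl in the same place, and in this assay compound 2 gives 5000 nM, the higher of the two numbers measured so far. Within the data shown here, the only step measured is a 4.2-fold higher number from compound 1 to compound 2 (0.62 log units; beyond the scatter), so compound 2 is the weaker of the pair by a margin beyond the scatter.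

Compound 3 `CCCCCCCCCCCCCCCCCCNC(=O)[C@H]1CSC(c2ccc(F)c(Br)c2)N1` differs from compound 2 in one place: 3-bromo-4-fluorophenyl in place of 4-cyanophenyl on a saturated ring carbon. Among the measured compounds shown here, the single measured step bears on this only loosely, since it shows that exchanging the aryl ring in this position can move the number by a modest amount, but no measured compound carries a halogenated phenyl, so the direction of the new change is not fixed by the data. A modest move is expected, with the number most likely settling somewhere near or a little below that of compound 2. Compound 3 is therefore estimated at 2500 nM, with a range from 700 nM to 8000 nM. The expected step is a 2.0-fold lower number from compound 2 to compound 3 (0.30 log units; within the scatter).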

Compound 3, half-maximal inhibitory concentration: 4700 nM
Estimate against measurement, compound 3: 1.9-fold (0.27 log units) below, within the range that was stated.
By their numbers in this assay, from the lowest: compound 1; then compounds 3 and 2 (each within the scatter of the next).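

In this assay, 3-bromo-4-fluorophenyl in place of 4-cyanophenyl gives a 1.1-fold lower number from compound 2 to compound 3 (0.03 log units; within the scatter) and so leaves the two compounds indistinguishable, even though one ring carries a nitrile with one hydrogen-bond acceptor and the other carries bromine and fluorine with none. Compound 1 remains apart, with a 3.9-fold higher number from compound 1 to compound 3 (0.59 log units; beyond the scatter) as a second measured step, so 3-hydroxyphenyl now gives the lowest number of the three, beyond the scatter of both other rings, and this position is shown to separate some aryl groups but not others. Nothing available here explains why these rings give the numbers they do.

The compounds shown leave open whether the hydroxyl group itself sets compound 1 apart, or whether an amine or a carboxylic acid on the same phenyl ring would give a similar number. What a shorter chain in place of the long one shared by all three would do to these numbers also remains an open question.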